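The compounds below may be only part of what the source reports. "The series", "measured", "known", "first", "only" and "open" are said of these compounds alone.

Compound 1, `C/C=C/C(=O)N(Cc1cccc(O)c1)c1cc(OC)c(OC)c(OC)c1`: 6700 nM
Compound 2, `COc1ccc(CNc2cc(OC)c(OC)c(OC)c2)cc1Br`: 48100 nM
Compound 3, `C/C=C/C(=O)N(Cc1ccc(OC)c(Br)c1)c1cc(OC)c(OC)c(OC)c1`: 2800 nM

These three compounds share a trimethoxyphenyl-bearing core and were tested in a functional assay on HCT-116 cells (Homo sapiens) for inhibition, read by MTT assay, with a stated time of 48 h; a lower number here means a stronger inhibitor, a higher number a weaker inhibitor. Compound 2 gives the highest number of the three; its nearest neighbour is compound 1, and the gap from compound 2 to compound 1 is beyond the scatter, as is the larger gap to compound 3, shown by a 17-fold lower number from compound 2 to compound 3 (1.23 log units; beyond the scatter). The other measured step, a 2.4-fold lower number from compound 1 to compound 3 (0.38 log units; beyond the scatter), is a modest one and changes the substituents on the benzyl ring.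

Compound 4, `COc1ccc(CNc2cc(OC)c(OC)c(OC)c2)cc1Cl`, has not yet been measured. It differs from compound 2 by chloro in place of bromo on an aromatic carbon. Neither measured step involves a halogen exchange: the step from compound 2 to compound 3 alters the nitrogen substituent, and the step from compound 1 to compound 3 replaces a whole substitution pattern. Going by the values given here, no measured step therefore bears directly on this change, and the expected step of a 1.0-fold lower number from compound 2 to compound 4 (0.00 log units; within the scatter) is none beyond the scatter. Compound 4 is estimated to give about 48000 nM, within a range of 20000 nM to 115000 nM.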

Compound 4, half-maximal inhibitory concentration: 41700 nM
Compound 4: the middle estimate sits 1.2-fold (0.06 log units) above what was measured; low and high end bracket the measured number.
By their numbers in this assay, from the lowest: compound 3; then compound 1; then compounds 4 and 2 (each within the scatter of the next).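

In this assay, chloro in place of bromo on this aromatic carbon, ortho to a methoxy group, gives a 1.2-fold lower number from compound 2 to compound 4 (0.06 log units; within the scatter), so the two halogens cannot be told apart here. The earlier steps shown here could not show this, since the bromo group only ever appeared as part of a whole substitution pattern set against another, while this comparison isolates the halogen alone, with a hydrogen on the nitrogen in both compounds. Nothing measured on these compounds accounts for this result.

The compounds shown leave open whether chloro and bromo would also stay within the scatter of each other with the (prop-1-en-1-yl)carbonyl group on the nitrogen, as in compound 3. They also leave open what fluoro, methyl or a nitrile would give on this aromatic carbon.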